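Changing the Amine Substituent from Carboxyphenyl to Methoxyphenyl

This account rests on a few compounds, and the source may have more. Where it says the series, first, only, none or still open, it means among the compounds named here.

Compound 1 `C=C1[C@@H](OC(C)=O)C[C@@H]2[C@](C)(COC=O)[C@H](OC(C)=O)CC[C@@]2(C)[C@@H]1C[C@@H](Nc1ccccc1C(=O)O)C1=CCOC1=O` was tested in a functional assay on HT-29 cells (Homo sapiens) for cytotoxicity, read by sulforhodamine B assay (a higher number here means a weaker inhibitor, a lower number a stronger inhibitor), where compound 1 gives 28700 nM. For the measured compounds named here, this is the highest of the three numbers measured so far: compound 2 `C=C1CC[C@@H]2[C@](C)(CO[Si](C)(C)C(C)(C)C)[C@H](OC(C)=O)CC[C@@]2(C)[C@@H]1C/C=C1/C(=O)OC[C@H]1OC(C)=O` gives 4690 nM and compound 3 `C=C1[C@@H](OC(C)=O)C[C@@H]2[C@](C)(CO[Si](C)(C)C(C)(C)C)[C@H](OC(C)=O)CC[C@@]2(C)[C@@H]1C[C@@H](Nc1ccc(C(=O)O)cc1)C1=CCOC1=O` gives 4630 nM, both of them lower than compound 1 by more than the usual scatter. Compounds 2 and 3 each differ from compound 1 in several places at once, so no single structural change can be read from either of them.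

Compound 4 `C=C1[C@@H](OC(C)=O)C[C@@H]2[C@](C)(COC=O)[C@H](OC(C)=O)CC[C@@]2(C)[C@@H]1C[C@@H](Nc1ccc(OC)cc1)C1=CCOC1=O` differs from compound 1 in one place: 4-methoxyphenyl in place of 2-carboxyphenyl on an amine nitrogen. Going by the values given here, no measured pair isolates this change. Still, a modest step toward a lower number is expected, a 2.4-fold lower number from compound 1 to compound 4 (0.38 log units; beyond the scatter), while a result within the scatter would not be surprising. Compound 4 is estimated at 12000 nM, with a likely range from 3500 nM to 40000 nM.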

Compound 4, half-maximal inhibitory concentration: 25400 nM
Compound 4: middle estimate off by 2.1-fold (0.33 log units), on the low side; the measured number falls inside the stated range.
By their numbers in this assay, from the lowest: compounds 3 and 2 (each within the scatter of the next); then compounds 4 and 1 (each within the scatter of the next).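

In this assay, 4-methoxyphenyl in place of 2-carboxyphenyl on the amine nitrogen gives a 1.1-fold lower number from compound 1 to compound 4 (0.05 log units; within the scatter) and so shows no readable change at this position. The carboxylic acid and its hydrogen-bond donor can therefore leave this nitrogen's substituent without moving the number, at least when 4-methoxyphenyl takes its place. No measurement at hand explains this flat result.

Still open, on these data alone, is what a plain phenyl, a pyridine or a simple alkyl chain on this nitrogen would give. Also open, as far as these compounds go, is whether any substituent here can shift the number beyond the scatter.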